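The compounds below may be only part of what the source reports. "The series", "measured", "known", "first", "only" and "open" are said of these compounds alone.

In an ADME assay on microsomes from liver (Mus musculus) for metabolic stability (on this read-out higher numbers stand for a longer-lived compound and lower numbers for a shorter-lived compound), compound 1 `CC(C)C(c1nnc[nH]1)c1ccc(-c2ccc3cccc(F)c3c2)[nH]c1=O` gives 0.213 h and compound 2 `CC(C)C(Cc1noc(=O)[nH]1)c1ccc(-c2ccc3cccc(F)c3c2)[nH]c1=O` gives 2.78 h as its reading. Compound 3 `CC(C)C(c1ncc[nH]1)c1ccc(-c2ccc3cccc(F)c3c2)[nH]c1=O` yields only a limit of the assay (< 0.0667 h) and no number. Both steps into it (an at least 3.1-fold lower number from compound 1 to compound 3 (0.50 log units; beyond the scatter)) and (an at least 41-fold lower number from compound 2 to compound 3 (1.61 log units; beyond the scatter)) lie beyond the scatter, so it stands lowest of the three. Compound 4 `CC(C)C(c1ccc(-c2ccc3cccc(F)c3c2)[nH]c1=O)N1CCNC1=O` brings one change (2-oxoimidazolidin-1-yl in place of 1H-imidazol-2-yl on a saturated chain carbon bound to an aromatic carbon and a saturated chain carbon) at that same place. Among the compounds with values here, no measured step makes this exchange, but groups at this place moved the read-out widely, as the step (a 13-fold higher number from compound 1 to compound 2 (1.12 log units; beyond the scatter)) shows. With compound 3 at its limit, a rise of moderate to large size is expected in this assay here, the expected step being (an at least 5.2-fold higher number from compound 3 to compound 4 (0.71 log units; beyond the scatter)). Compound 4 is estimated at 0.35 h with an expected range from 0.08 h to (1.5 h).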

Compound 4, half-life: 0.682 h
Compound 4: the middle estimate sits 1.9-fold (0.29 log units) below what was measured; the measured number falls inside the stated range.
By their numbers in this assay, from the lowest: compound 1; then compound 4; then compound 2. At a limit, below all of these: compound 3.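

In this assay, a five-membered non-aromatic ring at this place gives a measured reading that lies among the aromatic rings: 2-oxoimidazolidin-1-yl yields an at least 10-fold higher number from compound 3 to compound 4 (1.00 log units; beyond the scatter) and a 3.2-fold higher number from compound 1 to compound 4 (0.51 log units; beyond the scatter), yet still a 4.1-fold lower number from compound 2 to compound 4 (0.61 log units; beyond the scatter). Compound 3 stands at a limit and not at a number: the limit of < 0.0667 h in this assay, at which 1 of the 4 values shown sits.

The compounds shown leave open how a carboxylic acid or a simple amine would read on this saturated chain carbon. They also do not separate the carbonyl from the loss of the aromatic ring; both enter together in this change.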